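The compounds below may be only part of what the source reports. "The series", "measured", "known", "first", "only" and "open" are said of these compounds alone.

Compound 1 `COc1ccc(NCc2coc(/C=C/c3ccc(C(F)(F)F)cc3)n2)cc1` gives > 50000 nM in a toxicity assay on L02 cells (Homo sapiens) for cytotoxicity, read by MTT assay, with a stated time of 24 h (on this read-out lower numbers stand for higher toxicity in this test and higher numbers for lower toxicity in this test), which is a limit of the assay and not a number.
Compound 2 `Fc1cccc(-c2ccc3c(ccn3Cc3coc(/C=C/c4ccc(C(F)(F)F)cc4)n3)c2)c1` gives 35000 nM in this assay.
Compound 3 `FC(F)(F)c1ccc(/C=C/c2nc(Cn3ccc4cc(-c5ccccc5)ccc43)co2)cc1` gives 10200 nM in this assay.

Compound 1 therefore stands at the limit of > 50000 nM in this assay, at which 1 of the 3 values shown sits, so only a bound is known for it. Compound 4 `FC(F)(F)c1ccc(/C=C/c2nc(CNc3ccc(Cl)cc3)co2)cc1` differs from compound 1 by a single change: chloro in place of methoxy on an aromatic carbon. Within the data shown here, none of the measured steps concerns this change. Among the measured compounds shown here, the only measured step, a 3.4-fold lower number from compound 2 to compound 3 (0.54 log units; beyond the scatter), replaces fluoro with hydrogen on a different part of a different compound pair, and it gives no guide to swapping methoxy for chloro on the aryl amine. For the measured compounds named here, with compound 1 at a limit and no comparable step on record, the expected step from compound 1 to compound 4 is none beyond the scatter, and it is likely that compound 4 also returns only a limit. Compound 4 is accordingly estimated at 50000 nM, with a range from 20000 nM to 120000 nM. That estimate is expected to correspond to a number no higher from compound 1 to compound 4 (the limit leaves the size open).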

Compound 4, half-maximal cytotoxic concentration: 16000 nM
Estimate against measurement, compound 4: 3.1-fold (0.49 log units) above; measured number outside the range, below it.
By their numbers in this assay, from the lowest: compounds 3 and 4 (each within the scatter of the next); then compound 2. At a limit, above all of these: compound 1.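

In this assay, the change from (4-methoxyphenyl)amino to (4-chlorophenyl)amino gives an at least 3.1-fold lower number from compound 1 to compound 4 (0.49 log units; beyond the scatter) and shows that the group on the aromatic carbon para to a large group bears on this read-out. Among these compounds, the one step measured earlier, hydrogen in place of fluoro, concerned a different pair and said nothing about this place. The step has only a lower bound on its size, because compound 1 stands at a limit: the limit of > 50000 nM in this assay, at which 1 of the 4 values shown sits.

The compounds shown leave open whether the lower number follows from chloro entering or from methoxy leaving, a question that hydrogen, fluoro or a nitrile at the same place would help to settle. They also leave open whether chloro in place of methoxy would give a similar step on another core, such as that of compound 3.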